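Moving the chlorine on the benzyl ether of an oxime

The compounds below may be only part of what the source reports. "The series", "measured", "known", "first", "only" and "open" are said of these compounds alone.

Compound 1 `Clc1ccccc1CO/N=C/c1c(-c2ccc3ccccc3c2)nc2occn12` was tested in an assay on HepG2 cells for agonist activity at nuclear receptor subfamily 1 group I member 3 (Homo sapiens), read by a luciferase reporter, with a stated time of 23 h (a lower number here means that less compound is needed, a higher number that more compound is needed for the effect), and gave 1100 nM. Among the numbers shown, compound 1 stands at the high end: the nearest is compound 2 `Clc1ccc(CO/N=C/c2c(-c3ccc4ccccc4c3)nc3sccn23)cc1Cl`, which in this assay gave 380 nM, a gap that lies beyond the usual scatter. Compound 3 `Clc1ccc(CO/N=C/c2c(-c3ccc(C4CCCCC4)cc3)nc3sccn23)cc1Cl` differs from compound 2 at the aryl group and reached only a limit of the assay; in this assay compound 3 gave > 100000 nM, so no number is known for it (the limit of > 100000 nM in this assay, at which 1 of the 3 values shown sits).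

Compound 4 `Clc1ccc(CO/N=C/c2c(-c3ccc4ccccc4c3)nc3occn23)cc1` keeps the core and the naphthyl group of compound 1 and changes only the benzyl ether: 4-chlorophenyl in place of 2-chlorophenyl on a saturated chain carbon bound to an oxygen on an unsaturated carbon. Going by the values given here, no pair of measured compounds differs in this one place, so the size of the step is not known from the data. Compound 2 carries chlorine at the 4-position of its own benzyl group and its value of 380 nM is the lower of the two measured numbers, but it also differs from compound 1 in the core, so it gives only a loose pointer. A modest gain or no change beyond the scatter is expected from compound 1 to compound 4, a 1.6-fold lower number from compound 1 to compound 4 (0.20 log units; within the scatter). For compound 4 a value of about 700 nM is estimated, within a range from 250 nM to 2500 nM.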

Compound 4, half-maximal effective concentration: 990 nM
Estimate against measurement, compound 4: 1.4-fold (0.15 log units) below; low and high end bracket the measured number.
By their numbers in this assay, from the lowest: compound 2; then compounds 4 and 1 (each within the scatter of the next). At a limit, above all of these: compound 3.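

In this assay the exchange of 2-chlorophenyl for 4-chlorophenyl amounts to a 1.1-fold lower number from compound 1 to compound 4 (0.05 log units; within the scatter) and is the first step shown that isolates this position. Going by these compounds alone, with the core and the naphthyl group held fixed, the two chlorophenyl groups cannot be told apart at this place, which the earlier compounds, differing from each other elsewhere or in more than one place, could not show. None of the evidence at hand bears on why this step is so small.

On these data alone, it remains open whether the chlorine matters at all here, which only the plain benzyl ether could settle on this core. Also open, as far as these compounds go, is how a methoxy group, an amine or a carboxylic acid on this phenyl ring, or a phenethyl ether in place of the benzyl ether, would read.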